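Thiophene replaces furan on the shared core

The source may report more compounds than this note shows. Statements on the series, on what has been measured and on what is new or still open speak of the compounds shown alone.

Compound 2 `O=C(O)/C=C/c1ccc(NC(=O)C2(NC(=O)c3ccc4c(c3)nc(-c3ccco3)n4C3CCCCC3)CCC2)cc1` carries a furan-2-yl group on the shared core. In an ADME assay on Huh-7 cells (Homo sapiens) for cytotoxicity (a lower number here means that less compound is tolerated, a higher number that more compound is tolerated), compound 2 gives only a limit, > 10 uM. Compound 1 `O=C(O)/C=C/c1ccc(NC(=O)C2(NC(=O)c3ccc4c(c3)nc(-c3cccs3)n4C3CCCCC3)CCC2)cc1` carries thiophen-2-yl in the same place; in this assay compound 1 also gives only a limit, > 10 uM. The step that the two limits leave unreadable from compound 1 to compound 2 is therefore not readable. Compound 3 `O=C(O)/C=C/c1ccc(NC(=O)C2(NC(=O)c3ccc4c(c3)nc(-c3ccccn3)n4C3CCCCC3)CCCC2)cc1` carries pyridin-2-yl and a larger saturated ring; in this assay compound 3 likewise gives only a limit, > 10 uM. Among the measured compounds shown here, all three measured values sit at the same limit (the limit of > 10 uM in this assay, at which 3 of the 3 values shown sit), so no measured step shows any readable size.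

Compound 4 `O=C(O)/C=C/c1ccc(NC(=O)C2(NC(=O)c3ccc4c(c3)nc(-c3ccsc3)n4C3CCCCC3)CCC2)cc1` differs from compound 2 by thiophen-3-yl in place of furan-2-yl on an aromatic carbon. For the measured compounds named here, the only step that bears on this change is the unreadable one from thiophen-2-yl to furan-2-yl, and because the limit of > 10 uM in this assay, at which 3 of the 3 values shown sit, holds all three values, no movement beyond the scatter is expected. Compound 4 is expected to give 30 uM in this assay, within 10 uM to 100 uM, so the estimated step that the limit leaves unreadable from compound 2 to compound 4 is none beyond the scatter, and a limit rather than a number is the likely read-out.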

Compound 4, half-maximal toxic concentration: > 10 uM
Compound 4 gave a limit, no number; the forecaster's own chance of this, stated with the estimate: 85%; the middle value lies beyond the limit too.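

The steps to compound 4 from compound 1 and from compound 2 cannot be read, since every compound shown in this assay sits at one limit: the limit of > 10 uM in this assay, at which 4 of the 4 values shown sit. The compounds shown leave open whether the group changed on the shared core affects tolerance at all.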